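The source may hold more compounds than are shown below. What is called first, only, known or untested is meant among the compounds shown, and "the series" means these compounds.

In an ADME assay on GES1 cells (Homo sapiens) for inhibition, read by MTT assay, with a stated time of 72 h (a higher number here means a weaker inhibitor, a lower number a stronger inhibitor), compound 1 `Cc1cc(Nc2cc(-c3ccccc3)[nH]n2)n2nc(SCc3ccc(F)cc3)nc2n1` gives 35500 nM. Compound 2 `C=CCSc1nc2nc(C)cc(Nc3cc(-c4ccccc4)[nH]n3)n2n1` is reported only as > 50000 nM, which is a limit of the assay and not a number. Compound 3 `Cc1cc(Nc2cc(-c3ccccc3)[nH]n2)n2nc(SCc3cccc4ccccc34)nc2n1` differs from compound 2 in one place: naphthalen-1-yl in place of vinyl on a saturated chain carbon bound to a sulfur. Going by the values given here, the one measured step that bears on this is an at least 1.4-fold higher number from compound 1 to compound 2 (0.14 log units; that floor lies within the scatter), where vinyl took the place of 4-fluorophenyl at that same place. Compound 3 again carries an aromatic group there, so a small move towards a lower number in this assay is expected, possibly none beyond the scatter. The estimated change is an at least 1.5-fold lower number from compound 2 to compound 3 (0.19 log units; that floor lies within the scatter). For compound 3 the expected value is 32000 nM, with an estimated range from 12000 nM to 60000 nM.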

Compound 3, half-maximal inhibitory concentration: 36300 nM
Compound 3: the middle estimate sits 1.1-fold (0.05 log units) below what was measured; low and high end bracket the measured number.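

In this assay, the place on a saturated chain carbon bound to a sulfur does not separate naphthalen-1-yl, with its 2 six-membered aromatic rings, from 4-fluorophenyl: the exchange gives a 1.0-fold higher number from compound 1 to compound 3 (0.01 log units; within the scatter). The exchange of vinyl for naphthalen-1-yl at that place gives an at least 1.3-fold lower number from compound 2 to compound 3 (0.13 log units; that floor lies within the scatter), so this step, like the earlier one from compound 1 to compound 2, supplies only a floor inside the scatter. Compound 2 is reported at a limit of the assay, which is not a number: the limit of > 50000 nM in this assay, at which 1 of the 3 values shown sits.

As far as these compounds go, it therefore remains open how far the vinyl-bearing compound 2 truly differs from the two compounds with aromatic groups at this place. The compounds shown also leave open whether an amine, a carboxylic acid or a longer chain there would move the number beyond the scatter in either direction.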